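Branching the amide chain of compound 2

The source may hold more compounds than are shown below. What is called first, only, known or untested is meant among the compounds shown, and "the series" means these compounds.

Measured in a functional assay on K562 cells (Homo sapiens) for antiproliferative activity, read by CCK-8 assay, with a stated time of 72 h (a higher number here means a weaker inhibitor of growth, a lower number a stronger inhibitor of growth), so far:
- Compound 1 `CC[C@@H]1C(=O)N(C)c2cnc(-n3ccc4cc(F)ccc43)nc2N1C1CCCC1` gives 21200 nM
- Compound 2 `CCCNC(=O)c1ccc2c(ccn2-c2ncc3c(n2)N(C2CCCC2)[C@H](CC)C(=O)N3C)c1` gives 395 nM

Compound 2 holds the lower of the two numbers. Compound 3 `CC[C@@H]1C(=O)N(C)c2cnc(-n3ccc4cc(C(=O)NCC(C)C)ccc43)nc2N1C1CCCC1` differs from compound 2 by methyl in place of hydrogen on a saturated chain carbon bound to two saturated chain carbons in one place, with methyl in place of hydrogen on a saturated chain carbon bound to two saturated chain carbons, so propyl becomes isobutyl. For the measured compounds named here, the only measured step of a 54-fold lower number from compound 1 to compound 2 (1.73 log units; beyond the scatter) came from replacing fluoro with propylcarbamoyl on an aromatic carbon and says little about branching. No step beyond the scatter is expected in this assay and no firm direction. The expected step of a 1.1-fold lower number from compound 2 to compound 3 (0.05 log units; within the scatter) stays within the scatter. Compound 3 is expected at 350 nM with a range of 150 nM to 800 nM as the working estimate.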

Compound 3, concentration for 50% growth inhibition: 638 nM
Compound 3: the middle estimate sits 1.8-fold (0.26 log units) below what was measured; the measured number falls inside the stated range.
By their numbers in this assay, from the lowest: compounds 2 and 3 (each within the scatter of the next); then compound 1.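

In this assay, methyl in place of hydrogen on a saturated chain carbon bound to two saturated chain carbons, which turns propyl into isobutyl, gives a 1.6-fold higher number from compound 2 to compound 3 (0.21 log units; within the scatter), so a single branch at this carbon makes no readable difference. The isobutylcarbamoyl group keeps the large separation from the fluoro compound, with a 33-fold lower number from compound 1 to compound 3 (1.52 log units; beyond the scatter). Nothing measured here accounts for either step.

From the compounds shown here alone, whether a longer chain, a cyclohexyl group or a chain ending in an amine would hold this level remains open. Going by these compounds, the role of the amide hydrogen also remains open.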